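The source may report more compounds than this note shows. Statements on the series, on what has been measured and on what is new or still open speak of the compounds shown alone.

Compound 1 `Cc1ccc(S/C(=C/c2sccc2C)C(=O)c2ccc(Br)cc2)cc1` — 50000 nM
Compound 2 `Cc1ccc(S/C(=C/c2c(O)cc(O)cc2O)C(=O)c2ccc(Br)cc2)cc1` — a limit, > 100000 nM
Compound 3 `Cc1ccc(S/C(=C/c2ccc(F)c(C)c2)C(=O)c2ccc(Br)cc2)cc1` — 25000 nM

In a functional assay on DU-145 cells (Homo sapiens) for inhibition, read by trypan blue exclusion, with a stated time of 96 h (on this read-out higher numbers stand for weaker inhibition of growth and lower numbers for stronger inhibition of growth), compound 1 gives 50000 nM. Compound 3 gives 25000 nM in this assay, a step of a 2.0-fold lower number from compound 1 to compound 3 (0.30 log units; within the scatter). Compound 2 reaches only the limit of this assay, > 100000 nM. Compound 1 thus holds the higher of the two numbers, with compound 3 within the usual scatter, and the third value being a limit (the limit of > 100000 nM in this assay, at which 1 of the 3 values shown sits).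

Compound 4 `Cc1ccc(S/C(=C/c2sccc2C)C(=O)c2ccc(Cl)cc2)cc1` is not yet measured. It differs from compound 1 by chloro in place of bromo on an aromatic carbon. For the measured compounds named here, none of the measured steps touches this position; all of them exchange the group on the double-bonded chain carbon. Nothing in the measured steps therefore predicts a change beyond the scatter, and compound 4 is expected to give about 50000 nM in this assay, between 18000 nM and 130000 nM, a step of no change at the digits printed from compound 1 to compound 4 (within the scatter).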

Compound 4, concentration for 50% growth inhibition: 50000 nM
The estimate for compound 4 equals the measured number at the digits printed, within the range that was stated.
By their numbers in this assay, from the lowest: compounds 3, 1 and 4 (each within the scatter of the next). At a limit, above all of these: compound 2.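

Exchanging bromo for chloro gives, in this assay, no change at the digits printed from compound 1 to compound 4 (within the scatter). For the compounds shown here, this is the first measured change on the aromatic carbon para to a large group, since all earlier steps exchanged the group on the double-bonded chain carbon. Nothing measured here gives a reason for this outcome.

The compounds shown leave open whether a different group at this place, such as an amine or a carboxylic acid, would shift the number beyond the scatter. They also leave open whether the same exchange reads alike with the 4-fluoro-3-methylphenyl group of compound 3 on the chain.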